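Indolyl hydrazone replacing catechol in the aryl-ether urea series

The compounds below may be only part of what the source reports. "The series", "measured", "known", "first", "only" and "open" are said of these compounds alone.

Measured compounds:
compound 1 `CN(C)CCn1cnnc1-c1cc(Oc2ccc(NC(=O)N/N=C/c3ccc(F)cc3Cl)cc2F)ccn1` — 2090 nM
compound 2 `CN(C)CCn1cnnc1-c1cc(Oc2ccc(NC(=O)N/N=C/c3ccc(O)c(O)c3)cc2F)ccn1` — "not determined" (no result reported)

The series shares one core with a hydrazone-linked aryl group at the far end. In an ADME assay on WI-38 cells (Homo sapiens) for cytotoxicity, read by MTT assay, with a stated time of 72 h (on this read-out higher numbers stand for weaker inhibition and lower numbers for stronger inhibition), compound 1 gives 2090 nM. In this assay compound 2 gives "not determined" (no result reported), so on the figures shown compound 2 stands nowhere: there is no value to compare with compound 1 and no step between the two measured compounds can be drawn.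

Compound 3 `CN(C)CCn1cnnc1-c1cc(Oc2ccc(NC(=O)N/N=C/c3c[nH]c4ccccc34)cc2F)ccn1` is the next member and is not yet measured. It differs from compound 2 as follows: 1H-indol-3-yl in place of 3,4-dihydroxyphenyl on a carbon with a double bond to nitrogen. Among the compounds with values here, because compound 2 has no value, the step from compound 2 to compound 3 in this assay cannot be sized from data; the only anchor is compound 1. The expectation is a step of no clear direction beyond the usual scatter relative to that anchor, since nothing in the series shows that swapping the hydrazone aryl group moves cytotoxicity much.

Compound 3 is therefore estimated at 3000 nM in this assay, with a range from 800 nM to 12000 nM.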

Compound 3, half-maximal inhibitory concentration: 3620 nM
Compound 3: middle estimate off by 1.2-fold (0.08 log units), on the low side; the range from low to high includes it.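

In this assay, 1H-indol-3-yl in place of 2-chloro-4-fluorophenyl on a carbon with a double bond to nitrogen gives a 1.7-fold higher number from compound 1 to compound 3 (0.24 log units; within the scatter). Within the data shown here, this is the first step that can be read at this position, and it shows that a group with a five-membered aromatic ring and a six-membered aromatic ring reads the same, within the scatter, as a single substituted six-membered aromatic ring, so this one exchange leaves the cytotoxicity read-out unmoved. Compound 2 has no number, so steps to or from it cannot be read and 3,4-dihydroxyphenyl remains unplaced, while no measurement on hand explains why compound 1 and compound 3 read alike.

One readable step between two aryl groups gives no trend for this position, and it cannot show whether the read-out stays flat across aromatic groups in general. Also open, going by these compounds, is whether a non-aromatic or charged end group, such as a carboxylic acid or a piperidine ring in place of the aryl group, would give a step beyond the scatter on the shared core.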